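The compounds below may be only part of what the source reports. "The series", "measured", "known", "first", "only" and "open" are said of these compounds alone.

Measured so far in a functional assay on MCF7 cells (Homo sapiens) for inhibition, read by MTT assay, with a stated time of 72 h; on this read-out higher numbers stand for weaker inhibition of growth and lower numbers for stronger inhibition of growth:
compound 1 `CC(C)=CCC/C(C)=C/CC/C(C)=C/C(=O)NC(=N)N`: 22000 nM
compound 2 `C=C1CCCC(C)(C)[C@@H]1CC/C(C)=C/C(=O)NC(=N)NC(=O)C=C(C)C`: 28100 nM

Compound 1 carries the lower of the two numbers, but its gap to compound 2 lies within the scatter, so the two read as alike. Compound 3 `CC(C)=CCC/C(C)=C/C(=O)NC(=N)N` is the next member, unmeasured. It differs from compound 1 by hydrogen in place of 3-methylbut-2-en-1-yl on a saturated chain carbon bound to a double-bonded chain carbon. Within the data shown here, no step between measured compounds covers such a change. Shortening the chain is expected to cost some growth inhibition in this assay, giving a step of a 1.8-fold higher number from compound 1 to compound 3 (0.26 log units; within the scatter) of modest size. Compound 3 is therefore estimated at 40000 nM, within 15000 nM to 110000 nM.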

Compound 3, concentration for 50% growth inhibition: 52200 nM
Compound 3: middle estimate off by 1.3-fold (0.12 log units), on the low side, and the stated range covers the measured number.
By their numbers in this assay, from the lowest: compounds 1, 2 and 3 (each within the scatter of the next, the first and the last beyond it).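

Among these compounds, replacing 3-methylbut-2-en-1-yl with hydrogen on a saturated chain carbon bound to a double-bonded chain carbon gives the only step that is read as beyond the scatter in this assay: a 2.4-fold higher number from compound 1 to compound 3 (0.38 log units; beyond the scatter). This position therefore responds to the change, with the shorter chain going with weaker inhibition of growth, though the step remains modest. No measurement on hand accounts for the step.

From the compounds shown here alone, it remains open whether a longer chain at this position would lower the number further. An amine or a carboxylic acid on the chain end is also untested by the compounds shown.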